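The source may report more compounds than this note shows. Statements on the series, on what has been measured and on what is new or still open speak of the compounds shown alone.

Series notes. In an assay on HEK293 cells for inhibition of Voltage-dependent T-type calcium channel subunit alpha-1G (Homo sapiens), read by fluorescence, tested at 10 uM (a higher number here means more inhibition at the concentration tested (going by the name of the read-out), a lower number less inhibition), compound 2 `CCCc1nc(-c2ccccc2)c(CNCCN2CCN(c3cccc(C)c3C)CC2)o1` gives 66.7%, the highest of the three numbers. Compound 3 `CCCc1nc(-c2ccccc2)c(CNCCCN2CCN(c3ccc(C)cc3)CC2)o1` gives 53.9% and compound 1 `CCCc1nc(-c2ccccc2)c(CNCCCN2CCN(c3cccc(OC)c3)CC2)o1` gives 36.4% in this assay; both stand below compound 2 beyond the scatter. Among the measured compounds shown here, the single step between measured compounds that differ in one place, a number 17.5 percentage points higher from compound 1 to compound 3 (beyond the scatter), is a modest gain on exchanging one aryl group on the ring amine nitrogen for another. Compound 4 `CCCc1nc(-c2ccccc2)c(CNCCN2CCN(c3ccc(F)cc3)CC2)o1` differs from compound 2 by 4-fluorophenyl in place of 2,3-dimethylphenyl on an amine nitrogen in a ring. For the measured compounds named here, no measured step covers this exchange; the step from compound 1 to compound 3 only shows that such aryl swaps move the read-out by a modest amount. A modest loss is therefore expected, a number 21.7 percentage points lower from compound 2 to compound 4 (beyond the scatter). Compound 4 is estimated at 45% in this assay, within 25% to 65%.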

Compound 4, a percentage reported as inhibition, at one concentration (the size of the read-out at that concentration, not a potency): 54.1%
The estimate for compound 4 lay 9.1 percentage points below the measured number, within the range that was stated.
By their numbers in this assay, from the lowest: compound 1; then compounds 3 and 4 (each within the scatter of the next); then compound 2.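

In this assay, 4-fluorophenyl in place of 2,3-dimethylphenyl gives a number 12.6 percentage points lower from compound 2 to compound 4 (beyond the scatter). The aryl group on the amine nitrogen in the ring thus moves the read-out beyond the scatter with the shorter chain of compounds 2 and 4, as well as with the longer chain of compounds 1 and 3. Nothing on hand accounts for the size of this loss. As far as these compounds go, the step changes the methyl groups and the fluorine together, and the share of each stays open. From the compounds shown here alone, how a 4-chlorophenyl group on this nitrogen would read also stays open.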